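A Nitro for Chloro Exchange on Compound 3

The source may hold more compounds than are shown below. What is called first, only, known or untested is meant among the compounds shown, and "the series" means these compounds.

Compound 1 `O=S(=O)(Nc1cccc2cc[nH]c12)c1ccc(Cl)cc1`: 6 ug/mL
Compound 2 `O=S(=O)(Nc1cc(Cl)cc2cc[nH]c12)c1ccc(Cl)cc1`: 9.1 ug/mL
Compound 3 `O=S(=O)(Nc1cccc2cc(O)[nH]c12)c1ccc(Cl)cc1`: 1.1 ug/mL

All three values come from a functional assay on KB cells (Homo sapiens) for antiproliferative activity, read by colorimetric assay and MTT assay; on this read-out higher numbers stand for weaker inhibition and lower numbers for stronger inhibition. Compound 3 gives the lowest number of the set, and its closest neighbour on the scale is compound 1, through a 5.5-fold lower number from compound 1 to compound 3 (0.74 log units; beyond the scatter). That step placed hydroxy in place of hydrogen on an aromatic carbon. The next change leads to compound 4 `O=[N+]([O-])c1ccc(S(=O)(=O)Nc2cccc3cc(O)[nH]c23)cc1` and is nitro in place of chloro on an aromatic carbon, para to a large group.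

For the measured compounds named here, no measured step covers this exchange. Going by the values given here, the only guidance is indirect, and both steps fall on a different part of the molecule. One is a 1.5-fold higher number from compound 1 to compound 2 (0.18 log units; within the scatter), for chloro in place of hydrogen on an aromatic carbon. The other is the hydroxy step from compound 1, which was modest. With so little to go on, no shift beyond the scatter is expected in this assay, and no direction can be favoured. The expected result is no change at the digits printed from compound 3 to compound 4 (within the scatter). Compound 4 is estimated at 1.1 ug/mL, with an expected range from 0.3 ug/mL to 4 ug/mL.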

Compound 4, half-maximal inhibitory concentration: > 100 ug/mL
Compound 4: no number, only a limit (the forecaster's own chance of this, stated with the estimate: 3%); at least 90-fold (1.95 log units) between middle value and limit.
By their numbers in this assay, from the lowest: compound 3; then compounds 1 and 2 (each within the scatter of the next). At a limit, above all of these: compound 4.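

In this assay compound 4 gives > 100 ug/mL, which is a limit of the assay and not a number. The earlier steps shown here all fell on another part of the molecule, and this first change at the position para to a large group, on the six-membered aromatic ring of carbon only, gives an at least 90-fold higher number from compound 3 to compound 4 (1.95 log units; beyond the scatter), a far larger step than either of those. The position is therefore sensitive to what sits there, even with the hydroxy group in place, and the size of the step is bounded from one side only: the limit of > 100 ug/mL in this assay, at which 1 of the 4 values shown sits.

With a single replacement shown at this position, it stays open whether the loss of activity belongs to nitro in particular or to any departure from chloro, and an amine, a nitrile or a methoxy group there would help to separate those two readings. Whether the same exchange would act alike on compound 1, which carries no hydroxy group, also stays open, as does the cause of the shift.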